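Working notes: nitro in place of chloro

The compounds below may be only part of what the source reports. "The series", "measured", "known", "first", "only" and "open" are said of these compounds alone.

Of the compounds shown here, three sharing one core have been read in a functional assay on MIA cells (Homo sapiens) for cytotoxicity, read by MTT assay, with a stated time of 72 h (a lower number here means a stronger inhibitor of growth, a higher number a weaker inhibitor of growth), so far. Compound 1 (`N#C/C(=C/c1ccc2ccccc2c1)C(=O)c1ccc[nH]1`) gives < 10000 nM here, which is a limit and not a number. Compound 2 (`Cc1ccc(/C=C(/C#N)C(=O)c2ccc[nH]2)cc1`) gives 27000 nM in this assay as a measured number. Compound 3 (`N#C/C(=C/c1ccc(Cl)cc1)C(=O)c1ccc[nH]1`) gives 59000 nM in the same read-out, the higher of the two measured numbers.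

Compound 4 (`N#C/C(=C/c1ccc([N+](=O)[O-])cc1)C(=O)c1ccc[nH]1`) carries nitro in place of chloro on an aromatic carbon, para to a large group, and the change counts as nitro in place of chloro on an aromatic carbon with the rest of the structure unchanged.

Among the measured compounds shown here, the only measured step bearing on this change is chloro in place of methyl, which gave a 2.2-fold higher number from compound 2 to compound 3 (0.34 log units; beyond the scatter) and counts as modest. One step of that size, on a different pair of groups, sets no direction for the exchange of chloro for nitro. In this assay, going by these compounds, no shift beyond the scatter is therefore expected, although a modest move either way remains open. The estimated change is a 1.2-fold lower number from compound 3 to compound 4 (0.07 log units; within the scatter) on present evidence. Compound 4 is expected at 50000 nM as an estimate, with an expected range from 17000 nM to 140000 nM.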

Compound 4, concentration for 50% growth inhibition: < 10000 nM
Compound 4: no number, only a limit (the forecaster's own chance of this, stated with the estimate: 15%); middle value at least 5.0-fold (0.69 log units) from the limit.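

In this assay, the aromatic carbon carrying these groups moves the number in both directions: the earlier pair showed only an upward step, whereas nitro in place of chloro gives an at least 5.9-fold lower number from compound 3 to compound 4 (0.77 log units; beyond the scatter). Nitro in place of methyl points the same way, with an at least 2.7-fold lower number from compound 2 to compound 4 (0.43 log units; beyond the scatter), so compound 4 lies on the lower side of both measured compounds that differ from it at this carbon, and the exchange of one group here can matter beyond the scatter. Both steps rest on a limit for compound 4 and not on a number, so they fix a direction and a minimum size, and the full size of the nitro change stays unknown: the limit of < 10000 nM in this assay, at which 2 of the 4 values shown sit.

The compounds shown do not tell how far below that limit compound 4 lies, nor what about the nitro group accounts for the step. Going by these compounds, whether an amine or a carboxylic acid on the same aromatic carbon would follow nitro or stay with chloro and methyl also remains open.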